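The source may hold more compounds than are shown below. What is called first, only, known or untested is meant among the compounds shown, and "the series" means these compounds.

Working notes on the series. Compound 1 `COc1cc(-c2noc(-c3ccc(NC(=O)OC(C)(C)C)cc3)n2)cc(OC)c1OC` and compound 2 `COc1cc(-c2noc(-c3ccc(N)cc3)n2)cc(OC)c1OC` share a core. In a functional assay on cells (Splenocyte, Mus musculus, strain BALB/c) for inhibition, read by scintillation counting and thymidine incorporation, with stated times of 48 h and 8 h (a higher number here means a weaker inhibitor, a lower number a stronger inhibitor), compound 1 gives 1600 nM and compound 2 gives 800 nM. The change between them is hydrogen in place of tert-butoxycarbonyl on a nitrogen on an aromatic ring and it made a step of a 2.0-fold lower number from compound 1 to compound 2 (0.30 log units; within the scatter). Compound 3 `COc1cc(-c2noc(C34CCC(NC(=O)OC(C)(C)C)(CC3)CC4)n2)cc(OC)c1OC` is built on a different core; how the two cores differ is not broken down here. In this assay compound 3 gives 2500 nM, which sits close to the value of compound 1 and is a larger gap away from the value of compound 2. Compound 4 `COc1cc(-c2noc(C34CCC(N)(CC3)CC4)n2)cc(OC)c1OC` is not yet measured; its change from compound 3 is hydrogen in place of tert-butoxycarbonyl on an amine nitrogen. This is the same kind of change as that from compound 1 to compound 2, not the same: there the nitrogen is on an aromatic ring whose other neighbours are aromatic carbon, here it is an amine nitrogen whose other neighbours are saturated ring carbon. Going by the values given here, only that one earlier instance is available to rest on, so the expected step from compound 3 to compound 4 in this assay is a 1.9-fold lower number from compound 3 to compound 4 (0.28 log units; within the scatter), roughly matching a 2.0-fold lower number from compound 1 to compound 2 (0.30 log units; within the scatter). Compound 4 is therefore estimated to give 1300 nM in this assay, plausibly between 500 nM and 4000 nM.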

Compound 4, half-maximal inhibitory concentration: 4800 nM
Beside the measured number, compound 4's estimate is 3.7-fold (0.57 log units) below it; measured number above the stated range.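

In this assay, hydrogen in place of tert-butoxycarbonyl on the amine nitrogen gives a 1.9-fold higher number from compound 3 to compound 4 (0.28 log units; within the scatter), and this does not match the earlier step on the other core: the same change on two cores in this assay, a 2.0-fold lower number (0.30 log units; within the scatter) from compound 1 to compound 2 and a 1.9-fold higher number (0.28 log units; within the scatter) from compound 3 to compound 4, 3.8-fold (0.58 log units) apart, beyond the scatter of two such steps. This change therefore cannot be carried as one fixed step from the core of compound 1 to the core of compound 3 in this series. Going by these compounds alone, each step alone lies within the scatter and each core offers only one pair, so the data show a disagreement between two steps, but neither a secure size or direction on either core nor any reason for the disagreement.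

Still open, going by these compounds, is whether the two cores also part when the tert-butoxycarbonyl group gives way to something other than hydrogen on the same nitrogen, such as an acetyl amide or a methyl carbamate. Also open, on these data alone, is how a carboxylic acid or a longer chain in that place would read on each core.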